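A few compounds are considered here, and "the series" means these few. Any claim that something is new, unique, unknown or untested is made for them only; others in the source may bear on it.

Measured compounds: compound 1 `CCCCCCCCCCCCCCNC(=O)[C@@H](N)[C@@H](C)O` gives 11000 nM; compound 2 `CCCCCCCCCCCCCCCCCCNC(=O)[C@@H](N)[C@@H](C)O` gives 39500 nM; compound 3 `CCCCCCCCCCCCCCNC(=O)[C@@H](NC(=O)c1cc2ccccc2n1C)[C@@H](C)O` gives 26500 nM.

In a functional assay on SiHa cells (Homo sapiens) for cytotoxicity, read by MTT assay, with a stated time of 48 h (on this read-out lower numbers stand for stronger inhibition and higher numbers for weaker inhibition), compound 2 holds the highest number of the three. From compound 1 to compound 2 the step was a 3.6-fold higher number from compound 1 to compound 2 (0.56 log units; beyond the scatter). Compound 4 `CCCCCCCCCCCCCCCCCCNC(=O)[C@@H](NC(=O)c1ccco1)[C@@H](C)O` differs from compound 2 by (furan-2-yl)carbonyl in place of hydrogen on an amine nitrogen. Among the compounds with values here, no measured step reports this exact change. The nearest comparison is between compound 1, which gives 11000 nM, and compound 3, which gives 26500 nM: acylation of the same amine nitrogen on the shorter chain went with a higher number. On that basis the step from compound 2 to compound 4 is expected to be a 1.4-fold higher number from compound 2 to compound 4 (0.14 log units; within the scatter), a small rise or none beyond the scatter. Compound 4 is therefore estimated at 55000 nM, between 20000 nM and 150000 nM.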

Compound 4, half-maximal inhibitory concentration: 13400 nM
Compound 4: middle estimate off by 4.1-fold (0.61 log units), on the high side; the whole stated range lies above it.
By their numbers in this assay, from the lowest: compounds 1, 4, 3 and 2 (each within the scatter of the next, the first and the last beyond it).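

In this assay, (furan-2-yl)carbonyl on the amine nitrogen of the longer-chain compound gave a 2.9-fold lower number from compound 2 to compound 4 (0.47 log units; beyond the scatter), so acylation at this nitrogen does not always go with a higher number. On the shorter chain, compound 1 gives 11000 nM and its acylated partner, compound 3, gives 26500 nM, so the two pairs run in opposite directions, though they differ in both chain and acyl group. No evidence at hand explains this difference.

The compounds shown leave open whether the chain or the acyl group sets the direction, since (furan-2-yl)carbonyl appears only on the longer chain. Going by these compounds, how an acetyl or benzoyl group on this nitrogen would read also remains open.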